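Adding a Cyano Group to Compound 3

The compounds below may be only part of what the source reports. "The series", "measured", "known", "first", "only" and "open" are said of these compounds alone.

In a functional assay on PANC-1 cells (Homo sapiens) for cytotoxicity, read by WST assay, with a stated time of 24 h (a higher number here means a weaker inhibitor, a lower number a stronger inhibitor), compound 1 `O=C(/C=C/CCCCCCc1ccccc1)Nc1ccccc1` gives > 100000 nM as a limit and not a number. Compound 2 `O=C(/C=C/CCCCCCc1ccccc1)NCc1ccccc1` gives > 100000 nM as a limit as well. Compound 3 `O=C(CCCCCCCCc1ccccc1)N1CCCCC1` likewise gives > 100000 nM as a limit. Compound 3 thus stands with the other two at the limit of > 100000 nM in this assay, at which 3 of the 3 values shown sit, and offers no exact number as a starting point.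

Compound 4 `N#Cc1ccc(CCCCCCCCC(=O)N2CCCCC2)cc1` follows from compound 3 through one change, (cyano in place of hydrogen on an aromatic carbon), that is, cyano in place of hydrogen on an aromatic carbon, para to a large group. Among the compounds with values here, the only measured step, a step that the two limits leave unreadable from compound 1 to compound 2, concerns a different part of the molecule, and its size cannot be read. Within the data shown here, no measured step therefore gives a size for this change. The expected result in this assay is no step beyond the scatter, and the estimate reads a number no higher from compound 3 to compound 4 (the limit leaves the size open) with no favoured direction. Compound 4 is estimated at 100000 nM with 40000 nM to 250000 nM as its expected range.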

Compound 4, half-maximal inhibitory concentration: > 100000 nM
Compound 4 gave a limit, no number; the forecaster's own chance of this, stated with the estimate: 80%; the middle value sits exactly at the limit.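

Compound 3 and compound 4 both rest at a limit and not at a number, so no new step can be read between them: the limit of > 100000 nM in this assay, at which 4 of the 4 values shown sit.

The compounds shown leave open whether any of these changes alters the result in this assay; none of them gives an exact number.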